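A few compounds are considered here, and "the series" means these few. Any claim that something is new, unique, unknown or untested is made for them only; others in the source may bear on it.

In an in vitro ADME assay on microsomes from liver (Homo sapiens) for pharmacokinetics (a higher number here means faster removal of the compound, a lower number slower removal), compound 2 (`O=C(N[C@@H](CCN1C[C@@H]2CN(C(=O)c3ccccn3)C[C@@H]2C1)c1cccc(F)c1)C1CCCC1`) gives 512 mL.min-1.g-1, the highest of the three measured numbers, against compound 3 (`O=C(N[C@@H](CCN1C[C@@H]2CN(C(=O)c3ccccn3)C[C@@H]2C1)c1cccc(F)c1)C1CCOC1`) at 55 mL.min-1.g-1 and compound 1 (`Cc1ncnc(C)c1C(=O)N1C[C@H]2CN(CC[C@H](NC(=O)C3CCOC3)c3ccccc3)C[C@H]2C1`) at 17 mL.min-1.g-1. Compound 4 (`O=C(N[C@@H](CCN1C[C@@H]2CN(C(=O)c3cnccn3)C[C@@H]2C1)c1cccc(F)c1)C1CCCC1`) keeps compound 2 except for one change, (pyrazin-2-yl in place of pyridin-2-yl on a carbonyl carbon), which puts pyrazin-2-yl in place of pyridin-2-yl on a carbonyl carbon. Within the data shown here, no measured step touches that group. The nearest evidence is a 9.3-fold lower number from compound 2 to compound 3 (0.97 log units; beyond the scatter), where oxolan-3-yl replaces cyclopentyl elsewhere in the molecule, so it bears only indirectly. On that basis, a lower number is expected, though by a smaller margin, and the expected change is a 2.3-fold lower number from compound 2 to compound 4 (0.37 log units; beyond the scatter). For compound 4 the estimated value is 220 mL.min-1.g-1, with an expected range of 90 mL.min-1.g-1 to 480 mL.min-1.g-1.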

Compound 4, intrinsic clearance in microsomes: 909 mL.min-1.g-1
Beside the measured number, compound 4's estimate is 4.1-fold (0.62 log units) below it, outside the stated range (above it).
By their numbers in this assay, from the lowest: compound 1; then compound 3; then compounds 2 and 4 (each within the scatter of the next).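

In this assay, among these compounds, pyrazin-2-yl in place of pyridin-2-yl on a carbonyl carbon gives a 1.8-fold higher number from compound 2 to compound 4 (0.25 log units; within the scatter), the first measured step at this place. Where oxolan-3-yl replaces cyclopentyl, the step is a 9.3-fold lower number from compound 2 to compound 3 (0.97 log units; beyond the scatter), whereas the exchange of these two aromatic rings stays within the scatter, so a second ring nitrogen here gives no readable difference. No measurement shown accounts for this result. Still open, from the compounds shown here alone, is whether pyrazin-2-yl gives the same picture with oxolan-3-yl in place of cyclopentyl. Also open, going by these compounds, is what a plain phenyl or a pyrimidin-2-yl group would give on this carbonyl carbon.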